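Trimming an Ether Chain Under a Cell Tolerance Ceiling

The source may hold more compounds than are shown below. What is called first, only, known or untested is meant among the compounds shown, and "the series" means these compounds.

Compound 1 `CC(C)OCCCNC(=O)c1csc(Nc2cc(Cl)c(Cl)c(Cl)c2)n1` is the starting point. In an ADME assay on MDCK cells (Canis lupus familiaris) for cytotoxicity, with a stated time of 48 h (a higher number here means that more compound is tolerated, a lower number that less compound is tolerated), compound 1 gives > 100000 nM, which is a limit of the assay rather than a number. Compound 2 `CCOCCCNC(=O)c1csc(Nc2cc(Cl)c(Cl)c(Cl)c2)n1` differs from it by hydrogen in place of methyl on a saturated chain carbon bound to an oxygen on a saturated carbon and a saturated chain carbon. In this assay compound 2 gives > 100000 nM, again only a limit. The step that the two limits leave unreadable from compound 1 to compound 2 therefore cannot be read. Compound 3 `Cc1cc(Nc2nc(C(=O)NCCCOC(C)C)cs2)ccc1Cl` rests on a different core; the difference between the two cores is not broken down here. In this assay compound 3 gives > 100000 nM, likewise a limit. Compound 4 `CCOCCCNC(=O)c1csc(Nc2ccc(Cl)c(C)c2)n1` differs from compound 3 by hydrogen in place of methyl on a saturated chain carbon bound to an oxygen on a saturated carbon and a saturated chain carbon, the same change made between compound 1 and compound 2. Because the limit of > 100000 nM in this assay, at which 3 of the 3 values shown sit, shows every measured value sitting at the ceiling, the step of a number no higher from compound 3 to compound 4 (the limit leaves the size open) is expected to be small. Compound 4 is estimated to give 100000 nM, most likely again reported only as a limit.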

Compound 4, half-maximal cytotoxic concentration: 52000 nM
The estimate for compound 4 lay 1.9-fold (0.28 log units) above the measured number; measured number inside the range.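

In this assay, trimming isopropoxy to ethoxy on the core of compound 3 gives an at least 1.9-fold lower number from compound 3 to compound 4 (0.28 log units; that floor lies within the scatter), so the measured drop alone does not establish a real loss of tolerance. On the core of compound 1, the same change joins two limits of the assay, and that step cannot be read. As far as these compounds go, whether the change behaves alike on the two cores therefore stays unknown, and the ceiling is what blocks the comparison: the limit of > 100000 nM in this assay, at which 3 of the 4 values shown sit.

The compounds shown leave open whether a longer chain or an amine would move the number on either core. They also leave open whether the trimmed chain lowers tolerance by more than the scatter on any core.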